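This account rests on a few compounds, and the source may have more. Where it says the series, first, only, none or still open, it means among the compounds named here.

Compound 1, `CCOC(=O)CN(Cc1ccccc1)c1nc(NCc2ccccc2)ncc1[N+](=O)[O-]`, was tested in a functional assay on MCF7 cells (Homo sapiens) for antiproliferative activity, read by MTT assay, with a stated time of 48 h; a higher number here means a weaker inhibitor, a lower number a stronger inhibitor. In this assay compound 1 gives > 100000 nM, which is a limit of the assay rather than a measured number. Compound 1 thus sits at the limit of > 100000 nM in this assay, at which 1 of the 2 values shown sits. For the measured compounds named here, compound 2, `COC(=O)CN(C)c1nc(Nc2ccc(Cl)cc2)ncc1[N+](=O)[O-]`, shares the core of compound 1 but differs at several places, so no single step links the two; in this assay compound 2 gives 60700 nM. Compound 3, `CCOC(=O)CN(Cc1ccccc1)c1nc(Nc2ccccc2)ncc1[N+](=O)[O-]`, has not yet been measured. It differs from compound 1 in one place: phenyl in place of benzyl on a nitrogen on an aromatic ring. Going by the values given here, no step between measured compounds covers this change, so its size cannot be read directly from the data. Because compound 2 gives 60700 nM while carrying an anilino group, compound 3 is expected to show a small gain over compound 1, possibly no larger than the scatter. The expected step is an at least 1.4-fold lower number from compound 1 to compound 3 (0.15 log units; that floor lies within the scatter). Compound 3 is estimated at 70000 nM, between 25000 nM and 200000 nM.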

Compound 3, half-maximal inhibitory concentration: > 100000 nM
Compound 3 gave a limit, no number (the forecaster's own chance of this, stated with the estimate: 40%); middle value at least 1.4-fold (0.15 log units) away from the limit.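

In this assay, for the compounds shown here, compound 1 and compound 3 both give a limit of the assay rather than a measured number, so no step from one to the other can be read: the limit of > 100000 nM in this assay, at which 2 of the 3 values shown sit. The compounds shown leave open whether phenyl in place of benzyl changes the antiproliferative activity at all.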